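From nitro to isopropyl: compound 3 to compound 4

A few compounds are considered here, and "the series" means these few. Any claim that something is new, unique, unknown or untested is made for them only; others in the source may bear on it.

In a functional assay (mast cells) for inhibition, with Rattus norvegicus as the target (a lower number here means that less compound is needed, a higher number that more compound is needed for the effect), compound 3 `CC1CC/C(=N\Nc2ccc([N+](=O)[O-])cc2)c2ncc(C(=O)O)c(=O)n21` gives 8900 nM as the highest of three numbers, against compound 1 `CC1CC/C(=N\Nc2ccc(Br)cc2)c2ncc(C(=O)O)c(=O)n21` at 2000 nM and compound 2 `CC1CC/C(=N\Nc2ccc(O)cc2)c2ncc(C(=O)O)c(=O)n21` at 1300 nM in the same read-out. Among the compounds with values here, compound 4 `CC(C)c1ccc(N/N=C2\CCC(C)n3c2ncc(C(=O)O)c3=O)cc1` has isopropyl in place of nitro on an aromatic carbon and no measured compound carries isopropyl. Within the data shown here, three measured steps bear on this change: a 4.5-fold higher number from compound 1 to compound 3 (0.65 log units; beyond the scatter) and a 6.8-fold higher number from compound 2 to compound 3 (0.84 log units; beyond the scatter) are both modest, while a 1.5-fold lower number from compound 1 to compound 2 (0.19 log units; within the scatter) stays within the scatter. Among these three compounds only the nitro compound stands apart, so a modest step to a lower number is expected, and a 3.2-fold lower number from compound 3 to compound 4 (0.50 log units; beyond the scatter) is the estimated step in this assay for this change. For compound 4 the estimate is 2800 nM with an expected range from 900 nM to 8000 nM in this read-out.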

Compound 4, half-maximal effective concentration: 1200 nM
Compound 4: middle estimate off by 2.3-fold (0.37 log units), on the high side, and the stated range covers the measured number.
By their numbers in this assay, from the lowest: compounds 4, 2 and 1 (each within the scatter of the next); then compound 3.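

In this assay isopropyl in place of nitro gives a 7.4-fold lower number from compound 3 to compound 4 (0.87 log units; beyond the scatter) on this aromatic carbon, para to a large group. Isopropyl in place of hydroxy gives a 1.1-fold lower number from compound 2 to compound 4 (0.03 log units; within the scatter) and in place of bromo gives a 1.7-fold lower number from compound 1 to compound 4 (0.22 log units; within the scatter) in the same read-out, so a group of carbon only joins hydroxy and bromo, and nitro alone stands apart.

Open, on these data alone, is whether an amine, a carboxylic acid or a longer alkyl chain here would stay with compounds 1, 2 and 4 or fall with compound 3. Nothing available gives a cause for the separate standing of the nitro compound.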